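The compounds below may be only part of what the source reports. "The series", "measured", "known", "first", "only" and "open" are said of these compounds alone.

Measured compounds:
Compound 1, `O=C(NC1CCCC1)c1ccc(C#Cc2cccnc2)nc1`: > 32000 nM
Compound 2, `Cc1ccc(C#Cc2ccc3c(n2)CCN(C)C3=O)cc1`: 7450 nM

For the measured compounds named here, in an assay on HEK293 cells for displacement of a labelled ligand from metabotropic glutamate receptor 5 (Homo sapiens), with a stated time of 2 h (a higher number here means a weaker inhibitor, a lower number a stronger inhibitor), compound 2 gives 7450 nM, the only plain number among the two values shown. For compound 1 the figure of > 32000 nM is a limit of the assay, not a measured number; it is the limit of > 32000 nM in this assay, at which 1 of the 2 values shown sits. Compound 3, `CN1CCc2nc(C#Cc3ccccn3)ccc2C1=O`, has not yet been measured. It differs from compound 2 in one place: pyridin-2-yl in place of 4-methylphenyl on a triple-bonded carbon. Going by the values given here, no pair of measured compounds shows this change on its own, so its size cannot be read from the data and can only be estimated. Compound 1, which also carries a pyridyl group on its triple bond but sits on a different core, reaches only a limit in this assay. The expectation is that compound 3 will be a weaker inhibitor than compound 2, by a step of a 2.7-fold higher number from compound 2 to compound 3 (0.43 log units; beyond the scatter), which would lie beyond the usual scatter. Compound 3 is therefore estimated at 20000 nM in this assay, within a range of 6000 nM to 40000 nM, with a fair chance that only a limit is reported.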

Compound 3, inhibition constant: 6240 nM
Estimate against measurement, compound 3: 3.2-fold (0.51 log units) above; low and high end bracket the measured number.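

In this assay, putting pyridin-2-yl in place of 4-methylphenyl on the triple-bonded carbon gives a 1.2-fold lower number from compound 2 to compound 3 (0.08 log units; within the scatter) and so leaves the two groups indistinguishable at this place on the shared core. For the compounds shown here, this is the first view of the change on its own: a ring with one nitrogen and a hydrogen-bond acceptor reads the same, within the scatter, as a carbon-only ring carrying a methyl group, and compound 3 gives a plain number rather than a limit even with a pyridyl group on its triple bond. Nothing in the data available explains why the two groups read alike.

Going by these compounds, the change alters two things at once, adding the ring nitrogen and removing the methyl group, so what each contributes stays open, and a plain phenyl group at this place would separate the two. Also open, on these data alone, is whether a fluorine atom or an amine on the pyridin-2-yl ring would move the value beyond the scatter.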